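Urea-linked anilinopyrimidines: swapping the aniline substituents

The source may hold more compounds than are shown below. What is called first, only, known or untested is meant among the compounds shown, and "the series" means these compounds.

Compound 1, `COc1cc(NC(=O)Nc2cc(Nc3ccc(OC)c(C)c3)ncn2)cc(OC)c1`, gives 39.7%.
Compound 2, `COc1ccc(F)cc1Nc1cc(NC(=O)Nc2c(Cl)cccc2Cl)ncn1`, gives 31.3%.
Compound 3, `COc1cc(Nc2cc(NC(=O)Nc3c(Cl)cccc3Cl)ncn2)cc(OC)c1`, gives 60%.

These three compounds were measured in a functional assay on NCI-H226 cells (Homo sapiens) for inhibition, read by MTT assay, with a stated time of 48 h, tested at 10 uM; a lower number here means less inhibition, a higher number more inhibition at the concentration tested (going by the name of the read-out). Among the three numbers, compound 1 stands second highest. Its nearest neighbour is compound 2, whose number lies lower by an amount within the usual scatter, so the two cannot be told apart. Compound 3 lies furthest away, higher by an amount beyond the scatter, so compound 3 gives the stronger inhibition of the two.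

The next compound, compound 4, `COc1cc(NC(=O)Nc2cc(Nc3ccc(C)c(F)c3)ncn2)cc(OC)c1`, is not yet measured. It differs from compound 1 in one place: 3-fluoro-4-methylphenyl in place of 4-methoxy-3-methylphenyl on a nitrogen on an aromatic ring. Among the compounds with values here, no measured pair in this set carries the same change, so the size of the step in this assay can only be guessed. The expectation is a step that stays within the scatter, with no clear direction, because compound 1 sits at 39.7% and nothing among the three numbers points to a large shift from this exchange. The estimated step from compound 1 to compound 4 is a number 1.7 percentage points lower from compound 1 to compound 4 (within the scatter). Compound 4 is therefore expected to give 38%, within a range from 22% to 55%.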

Compound 4, a percentage reported as inhibition, at one concentration (the size of the read-out at that concentration, not a potency): 39.7%
Compound 4: middle estimate off by 1.7 percentage points, on the low side, and the stated range covers the measured number.
By their numbers in this assay, from the lowest: compounds 2, 1 and 4 (each within the scatter of the next); then compound 3.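

In this assay, within the data shown here, 3-fluoro-4-methylphenyl in place of 4-methoxy-3-methylphenyl on a nitrogen on an aromatic ring gives no change at the digits printed from compound 1 to compound 4 (within the scatter) as the first step in this set that can be read at a single place. In this one pair, the oxygen of the leaving group goes and a fluorine enters without the number moving beyond the scatter, so the number stays level for this particular exchange on the urea partner carried by compound 1. Nothing available explains this outcome.

The compounds shown leave open whether the same exchange would also leave the number unmoved in the presence of the other urea partner, the one carried by compound 2 and compound 3. They also leave open whether an amine or a carboxylic acid on this aromatic ring would shift the inhibition.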